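This account rests on a few compounds, and the source may have more. Where it says the series, first, only, none or still open, it means among the compounds named here.

Measured compounds in an ADME assay on the whole organism with Oryza sativa as the target, tested at 0.1 uM; on this read-out lower numbers stand for a stronger effect and higher numbers for a weaker effect at the one concentration tested:
compound 1 `C[C@H](NC(=O)Nc1ccccc1C(F)(F)F)c1ccccc1` gives 97%
compound 2 `C[C@@H](NC(=O)Nc1cccc(C(F)(F)F)c1)c1ccccc1` gives 82%
compound 3 `C[C@H](NC(=O)Nc1cccc(C(F)(F)F)c1)c1ccccc1` gives 94%

Compound 2 stands lowest of the three numbers in this assay; its nearest neighbour is compound 3, its furthest compound 1, both beyond the scatter. For the measured compounds named here, the only step between measured compounds that differ in one place is a number 12 percentage points higher from compound 2 to compound 3 (beyond the scatter), and that step reflects the fact that compounds 2 and 3 differ only in the configuration as drawn alone; it says nothing about a change of substituent on the ring.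

Compound 4 `C[C@@H](NC(=O)Nc1cccc(I)c1)c1ccccc1` is still to be measured in this assay. Against compound 2 the change is iodo in place of trifluoromethyl on an aromatic carbon. Going by the values given here, no measured step bears on this exchange: compounds 1 and 3 differ from compound 2 in the position of the trifluoromethyl or in configuration, not in the identity of the group. With nothing to go on, the working expectation is a step of about none beyond the scatter, so a number 1 percentage points higher from compound 2 to compound 4 (within the scatter) is the estimate, with a wide range to cover the uncertainty.

Compound 4 is therefore expected to give 83% in this assay, between 62% and 98%.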

Compound 4, a percentage reported as activity, at one concentration (the size of the read-out at that concentration, not a potency): 81%
The estimate for compound 4 lay 2 percentage points above the measured number; low and high end bracket the measured number.
By their numbers in this assay, from the lowest: compounds 4 and 2 (each within the scatter of the next); then compounds 3 and 1 (each within the scatter of the next).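

The exchange of trifluoromethyl for iodo on an aromatic carbon, meta to a large group, gives a number 1 percentage points lower from compound 2 to compound 4 (within the scatter) in this assay. For the compounds shown here, this is the first reading of a change of group at this position: with the configuration of compound 2 kept, a substituent of 4 heavy atoms gives way to one of 1 heavy atom, and the read-out separates the two compounds by no more than the scatter. Nothing at hand offers an explanation for this result.

The compounds shown leave open whether the same exchange reads alike in the configuration of compound 3 or at the trifluoromethyl position of compound 1. They also leave open how an amine, a carboxylic acid or a methoxy group would read at this position.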